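Methylphenyl isomers: from compound 3 to compound 4

The source may hold more compounds than are shown below. What is called first, only, known or untested is meant among the compounds shown, and "the series" means these compounds.

In a physicochemical assay for metabolic stability, read by HPLC, at pH 4.5, tested at 10 uM (on this read-out lower numbers stand for a shorter-lived compound and higher numbers for a longer-lived compound), compound 2 `Cc1ccccc1CNC(=O)n1c(N)nc2ccccc21` gives 0.45 h and compound 3 `Cc1ccc(CNC(=O)n2c(N)nc3ccccc32)cc1` gives 0.567 h. For the measured compounds named here, these are the only two numbers so far and they lie within the scatter of each other, so compound 3 stands level with compound 2. Compound 1 `Cc1cccc(CNC(=O)n2cnc3ccccc32)c1` gives only a limit of the assay, > 2 h.

Next is compound 4 `Cc1cccc(CNC(=O)n2c(N)nc3ccccc32)c1`, with 3-methylphenyl in place of 4-methylphenyl on a saturated chain carbon bound to an amide-type nitrogen. Going by the values given here, the one measured step at this place, a 1.3-fold higher number from compound 2 to compound 3 (0.10 log units; within the scatter), exchanged 2-methylphenyl for 4-methylphenyl and stayed inside the scatter. Compound 4 carries the remaining isomer, so with compound 3 at 0.567 h no step beyond the scatter is expected in this assay. The expected change is a 1.1-fold lower number from compound 3 to compound 4 (0.04 log units; within the scatter). For compound 4 the estimated half-life is 0.52 h, with an expected range from 0.3 h to 0.9 h.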

Compound 4, half-life: 0.45 h
The estimate for compound 4 lay 1.2-fold (0.06 log units) above the measured number; low and high end bracket the measured number.
By their numbers in this assay, from the lowest: compounds 2, 4 and 3 (each within the scatter of the next). At a limit, above all of these: compound 1.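

With this result all three methylphenyl isomers on a saturated chain carbon bound to an amide-type nitrogen have a reading in this assay, and the two new steps among them, a 1.3-fold lower number from compound 3 to compound 4 (0.10 log units; within the scatter) and no change at the digits printed from compound 2 to compound 4 (within the scatter), give no sign that the half-life depends on where the methyl group sits. For the compounds shown here, the amino group gives the first step beyond the scatter, with amino in place of hydrogen on an aromatic carbon: an at least 4.4-fold lower number from compound 1 to compound 4 (0.64 log units; beyond the scatter). Compound 1 stands at a limit of the assay, so this step has a limit at one end: the limit of > 2 h in this assay, at which 1 of the 4 values shown sits.

From the compounds shown here alone, only the 3-methylphenyl compounds form a pair for this amino change, so the same change with 2-methylphenyl or 4-methylphenyl stays open. Also open, going by these compounds, is how the half-life would respond to chloro in place of methyl, or to a longer chain in place of the saturated chain carbon.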